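The compounds below may be only part of what the source reports. "The series", "measured", "known", "first", "only" and "open" are said of these compounds alone.

Compound 1 `O=[N+]([O-])c1ccccc1NN=C(c1ccc(O)cc1)c1ccc(O)cc1` and compound 2 `Cc1ccc(NN=C(c2ccc(O)cc2)c2ccc(O)cc2)c(C)c1` each carry two hydroxy groups on the shared core. In a functional assay on cells (Melanoma tumor cell line, Homo sapiens) for cytotoxicity (a lower number here means a stronger inhibitor, a higher number a weaker inhibitor), compound 1 gives 3.9 ug/mL, and compound 2 gives 10 ug/mL. Compound 3 `O=[N+]([O-])c1ccc(NN=C(c2ccccc2)c2ccccc2)c([N+](=O)[O-])c1` carries no hydroxy group, and in this assay it yields only a limit, > 5 ug/mL, not a number. Compound 3 thus stands at the limit of > 5 ug/mL in this assay, at which 1 of the 3 values shown sits. Compound 4 `O=[N+]([O-])c1ccc(N/N=C(\c2ccccc2)c2ccc(O)cc2)c([N+](=O)[O-])c1` differs from compound 3 by hydroxy in place of hydrogen on an aromatic carbon. Since compound 1 and compound 2, which both carry hydroxy groups, give numbers rather than limits in this assay, a step toward stronger inhibition, larger than the usual scatter, is expected from compound 3 to compound 4 a step that the limit leaves unreadable from compound 3 to compound 4. For compound 4 the estimated value in this assay is 7 ug/mL, expected between 2.5 ug/mL and 20 ug/mL.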

Compound 4, half-maximal inhibitory concentration: 5 ug/mL
Compound 4: the middle estimate sits 1.4-fold (0.15 log units) above what was measured; low and high end bracket the measured number.
By their numbers in this assay, from the lowest: compounds 1, 4 and 2 (each within the scatter of the next, the first and the last beyond it).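

Hydroxy in place of hydrogen on an aromatic carbon, para to a large group, gives in this assay a number no higher from compound 3 to compound 4 (the limit leaves the size open). Compound 4 thus shows that this single change on the side carrying the nitro groups yields a number, 5 ug/mL, though the size of the step cannot be read. The value of compound 3 is a limit, not a number: the limit of > 5 ug/mL in this assay, at which 1 of the 4 values shown sits.

The compounds shown leave open how an amine, a methoxy group or a carboxylic acid at this place would read. They also leave open what hydroxy does here when compared with a number rather than a limit.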